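The compounds below may be only part of what the source reports. "The series", "measured", "known", "first", "only" and "open" are said of these compounds alone.

Compound 1 `CC1=C(/C=C/C(=O)/C=C/c2cccc(C(F)(F)F)c2)C(C)(C)CCC1` gives 7700 nM in a functional assay on PC-3 cells (Homo sapiens) for cytotoxicity, read by MTT assay, with a stated time of 72 h; on this read-out higher numbers stand for weaker inhibition and lower numbers for stronger inhibition.
Compound 2 `CC1=C(/C=C/C(=O)/C=C/c2cccc(F)c2)C(C)(C)CCC1` gives 18700 nM in this assay.
Compound 3 `CC1=CCCC(C)(C)C1/C=C/C(=O)/C=C/c1ccccc1C(F)(F)F` gives 19000 nM in this assay.

Compound 1 and compound 2 share one core and differ in a single place: fluoro in place of trifluoromethyl on an aromatic carbon. That change produced a 2.4-fold higher number from compound 1 to compound 2 (0.39 log units; beyond the scatter), so the larger group is the one that goes with the lower number here. Compound 3 is built from the same atoms as compound 1, joined differently; the difference between the two cores is not broken down here. The numbers for compound 3 and compound 2 lie within the usual scatter of each other.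

Compound 4 `CC1=CCCC(C)(C)C1/C=C/C(=O)/C=C/c1ccccc1F` has not yet been measured in this assay. It differs from compound 3 in the same way: fluoro in place of trifluoromethyl on an aromatic carbon. The surroundings are not identical, since in compound 1 the place is meta to a large group while in compound 3 it is ortho to a large group, so this is the same kind of change rather than the same one. The step from compound 3 to compound 4 is expected to be a 2.2-fold higher number from compound 3 to compound 4 (0.34 log units; beyond the scatter), resting on the earlier step because a 2.4-fold higher number from compound 1 to compound 2 (0.39 log units; beyond the scatter) points to a weaker result after this swap. Compound 4 is accordingly estimated at 42000 nM, with a range from 16000 nM to 110000 nM.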

Compound 4, half-maximal inhibitory concentration: 4800 nM
Compound 4: the middle estimate sits 8.8-fold (0.94 log units) above what was measured; measured number below the stated range.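

Replacing trifluoromethyl with fluoro gives a 4.0-fold lower number from compound 3 to compound 4 (0.60 log units; beyond the scatter) in this assay and so runs in the opposite direction to the earlier step on the core of compound 1. The gap between the two steps is larger than repeat measurements would explain: the same change on two cores in this assay, a 2.4-fold higher number (0.39 log units; beyond the scatter) from compound 1 to compound 2 and a 4.0-fold lower number (0.60 log units; beyond the scatter) from compound 3 to compound 4, 9.6-fold (0.98 log units) apart, beyond the scatter of two such steps. For these two pairs, then, the result of the swap on one core does not predict even its direction on the other, but two pairs cannot show whether the reversal comes from the joining of the cores or from where the group sits on the aromatic ring, since both differ at once.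

Going by these compounds, whether the reversal extends to other groups remains open, as only trifluoromethyl and fluoro are compared here, and a chloro, methoxy or amine group in the same place could show whether they follow the trend of either core. Also open, on these data alone, is how each core behaves with the same group moved to another place on the aromatic ring.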